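Halogen swap on the benzylidene arm of compound 2

The compounds below may be only part of what the source reports. "The series", "measured", "known", "first", "only" and "open" are said of these compounds alone.

Measured so far:
compound 1 `COc1ccccc1/C=c1\c(=O)[nH]/c(=C/c2cccc(Cl)c2Cl)c(=O)n1C` — 200 nM
compound 2 `C=CCn1c(=O)/c(=C\c2cccc(F)c2)[nH]c(=O)/c1=C\c1ccccc1OC` — 8890 nM

In a functional assay on HL-60 cells (Homo sapiens) for cytotoxicity, read by CCK-8 assay, with a stated time of 72 h (on this read-out higher numbers stand for weaker inhibition and lower numbers for stronger inhibition), compound 2 gives 8890 nM, the higher of the two numbers recorded; compound 1 gives 200 nM, and the gap between them is well beyond the usual scatter. Within the data shown here, compound 1 differs from compound 2 in more than one place, so the two values are compared only as they stand, and no single step can be drawn between them.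

Compound 3 `C=CCn1c(=O)/c(=C\c2cccc(Br)c2)[nH]c(=O)/c1=C\c1ccccc1OC` has not been measured. It keeps the core and the allyl group of compound 2 and changes one substituent: bromo in place of fluoro on an aromatic carbon. Among the measured compounds shown here, no measured pair isolates a bromo for fluoro exchange, so there is no step in this assay to rest on. With nothing to point in either direction, the expectation is a step from compound 2 to compound 3 that stays within the scatter, with a slight lean toward a lower number; the expected step is a 1.5-fold lower number from compound 2 to compound 3 (0.17 log units; within the scatter). Compound 3 is therefore estimated at 6000 nM, with a range from 2000 nM to 20000 nM.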

Compound 3, half-maximal inhibitory concentration: 5200 nM
For compound 3 the middle estimate is 1.2-fold (0.06 log units) above the measured one, within the range that was stated.
By their numbers in this assay, from the lowest: compound 1; then compounds 3 and 2 (each within the scatter of the next).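

In this assay, among these compounds, the only pair so far that differs in one place exchanges 3-fluorophenyl for 3-bromophenyl on an aromatic carbon, meta to a large group, and the step is within the scatter (a 1.7-fold lower number from compound 2 to compound 3 (0.23 log units; within the scatter)). This gives the series its first reading at this position: with the core, the allyl group and the methoxy-bearing arm held constant, fluoro and bromo cannot be told apart here, and compound 3, at 5200 nM, remains on the same level as compound 2. The reading covers these two halogens at this one position only, and no measurement offers an explanation for it.

On these data alone, whether a group of another kind at this carbon, such as an amine, a nitrile or a carboxylic acid, would give a number within the scatter of these two values remains open. Among the compounds shown here, also open is how much the allyl group contributes, since no pair yet sets it against a methyl group or a longer chain with the rest of the structure unchanged.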